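From methyl to isopropyl on the shared core

This account rests on a few compounds, and the source may have more. Where it says the series, first, only, none or still open, it means among the compounds named here.

Measured in an ADME assay on J774.A1 cells (Mus musculus) for cytotoxicity, read by fluorescence and resazurin assay, with a stated time of 24 h; on this read-out lower numbers stand for stronger inhibition and higher numbers for weaker inhibition:
compound 1 `CNC(=O)c1c(C(C)C)oc2nc(N3CCCC3)ccc12`: "not determined" (no result reported)
compound 2 `CNC(=O)c1c(C)oc2nc(N3CCCC3)ccc12`: "not determined" (no result reported)
compound 3 `CCOC(=O)c1c(C)oc2nccc(N3CCN(c4ccccc4)CC3)c12`: 120000 nM

For the measured compounds named here, compound 3 holds the only number here, which leaves nothing to rank it against. Compound 4 `CCOC(=O)c1c(C(C)C)oc2nccc(N3CCN(c4ccccc4)CC3)c12` differs from it in one place, isopropyl in place of methyl on an aromatic carbon, next to the ring oxygen. Going by the values given here, no measured pair shows what this exchange does, so the expectation rests on compound 3 alone, at 120000 nM. A small move toward lower numbers in this assay is expected, scarcely beyond the usual scatter. The estimated change is a 1.3-fold lower number from compound 3 to compound 4 (0.12 log units; within the scatter). For compound 4 the expected value is 90000 nM, within an estimated range from 35000 nM to 200000 nM.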

Compound 4, half-maximal inhibitory concentration: 235000 nM
Beside the measured number, compound 4's estimate is 2.6-fold (0.42 log units) below it, and the stated range ends below it.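

In this assay, for the compounds shown here, the exchange of methyl for isopropyl next to the ring oxygen gives a 2.0-fold higher number from compound 3 to compound 4 (0.29 log units; within the scatter), the first reading at this position, and it stays within the scatter on the ester-bearing compounds. Nothing available explains this result. The same exchange between compound 2 and compound 1 cannot be read, since neither entry holds a number. From the compounds shown here alone, whether a longer chain or a phenyl group at this position, or a carboxylic acid in place of the ethoxycarbonyl group, would move the value remains open.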